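This account rests on a few compounds, and the source may have more. Where it says the series, first, only, none or still open, it means among the compounds named here.

Compound 1 `CNC(=O)c1cccn(Cc2ccccc2)c1=O` gives 3 in a physicochemical assay for lipophilicity, at pH 7.4; on this read-out higher numbers stand for higher lipophilicity and lower numbers for lower lipophilicity.
Compound 2 `CNC(=O)c1cc(C(=O)NC2CC2)cn(Cc2ccc3nc[nH]c3c2)c1=O` gives 1.2 in this assay.
Compound 3 `CNC(=O)c1cc(C(N)=O)cn(Cc2ccccc2)c1=O` gives 2 in this assay.

Compound 2 stands lowest of the three in this assay; compound 3 is nearest to it and compound 1 furthest, both clearly higher. For the measured compounds named here, the only measured step, a number 1.00 log units lower from compound 1 to compound 3 (beyond the scatter), concerns a carbamoyl group and does not touch the change at hand. Compound 4 `CNC(=O)c1cc(C(=O)NC2CC2)cn(Cc2cccc3[nH]ncc23)c1=O` differs from compound 2 by 1H-indazol-4-yl in place of 1H-benzimidazol-6-yl on a saturated chain carbon bound to an aromatic nitrogen; the two have the same atoms, joined differently. Going by the values given here, no measured step bears on this change, so the expectation rests on the two groups being so alike in what they count. A step of a number 0.30 log units higher from compound 2 to compound 4 (within the scatter) in this assay is expected, within or barely beyond the scatter. Compound 4 is estimated at 1.5, between 1.1 and 1.9.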

Compound 4, distribution coefficient: 1.5
Beside the measured number, compound 4's estimate shows no gap at the digits printed; measured number inside the range.
By their numbers in this assay, from the lowest: compounds 2 and 4 (each within the scatter of the next); then compound 3; then compound 1.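

In this assay putting 1H-indazol-4-yl in place of 1H-benzimidazol-6-yl on a saturated chain carbon bound to an aromatic nitrogen gives a number 0.30 log units higher from compound 2 to compound 4 (within the scatter) and so these two groups, with the same atoms joined differently, cannot be told apart on this read-out. This is the first step shown at this position, as the earlier step concerned a carbamoyl group on an aromatic carbon. Nothing available explains the result.

Going by these compounds, whether a carboxylic acid or an amine at this position would shift the number beyond the scatter remains open.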